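A Smaller Amide on the Same Ring

This account rests on a few compounds, and the source may have more. Where it says the series, first, only, none or still open, it means among the compounds named here.

Values in a functional assay on HCT-116 cells (Homo sapiens) for inhibition (on this read-out lower numbers stand for an effect already at smaller amounts and higher numbers for an effect only at larger amounts of compound), are:
- compound 1 `CCN(CC)CC1CCN(c2ccc(Nc3nc(NC4CCCCC4)c4nc[nH]c4n3)c(OC)c2)CC1` gives 55 nM
- compound 2 `COc1cc(N2CCC(CC(=O)N3CCC(N(C)C)C3)CC2)ccc1Nc1nc(NC2CCCCC2)c2nc[nH]c2n1` gives 97 nM

Compound 2 cannot be told apart from compound 1 on these numbers, since a 1.8-fold higher number from compound 1 to compound 2 (0.25 log units; within the scatter) stays within the scatter. The next compound is compound 3 `COc1cc(N2CCC(C(=O)N3CC(O)C3)CC2)ccc1Nc1nc(NC2CCCCC2)c2nc[nH]c2n1`, not yet measured. Its change from compound 2 is (3-hydroxyazetidin-1-yl)carbonyl in place of ((3-(dimethylamino)pyrrolidin-1-yl)carbonyl)methyl on a saturated ring carbon. Within the data shown here, only one measured step bears on this, a 1.8-fold higher number from compound 1 to compound 2 (0.25 log units; within the scatter), and it altered the group on a saturated chain carbon. Among the measured compounds shown here, no measured compound carries the new group, so the guide is weak. At most a modest rise in this assay is expected, with no firm step beyond the scatter. The estimated step is a 1.4-fold higher number from compound 2 to compound 3 (0.16 log units; within the scatter) as a rough expectation. Compound 3 is estimated at 140 nM with an expected range of 50 nM to 400 nM in this read-out.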

Compound 3, half-maximal effective concentration: 260 nM
Compound 3: the middle estimate sits 1.9-fold (0.27 log units) below what was measured; low and high end bracket the measured number.
By their numbers in this assay, from the lowest: compounds 1 and 2 (each within the scatter of the next); then compound 3.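

In this assay, the swap at this saturated ring carbon gave a 2.7-fold higher number from compound 2 to compound 3 (0.43 log units; beyond the scatter), and the comparison with the (diethylamino)methyl group gave a 4.7-fold higher number from compound 1 to compound 3 (0.67 log units; beyond the scatter). The number therefore does respond to the group placed here: the two groups compared earlier stayed within the scatter of each other, whereas the (3-hydroxyazetidin-1-yl)carbonyl group puts compound 3 clearly highest of the three. Nothing measured here accounts for this rise.

The step from compound 2 changes several things at once, including the dimethylamino group, the ring size, the methyl link and the hydroxyl, so it does not show which of them counts. Going by these compounds, a (3-(dimethylamino)azetidin-1-yl)carbonyl group or a ((3-hydroxyazetidin-1-yl)carbonyl)methyl group on this ring carbon could begin to separate these, and how either would read remains open.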